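Carboxy to ethylcarbamoyl, starting from a compound without a number

A few compounds are considered here, and "the series" means these few. Any claim that something is new, unique, unknown or untested is made for them only; others in the source may bear on it.

Compound 1 (`CCNC(=O)c1noc(-c2cc(C(C)C)c(O)cc2O)c1-c1cc(CN(C)C)no1`) gives 92 nM
Compound 2 (`CCNC(=O)c1noc(-c2cc(C(C)C)c(O)cc2O)c1-c1cc(C(=O)O)no1`) gives "not determined" (no result reported)
Compound 3 (`CCNC(=O)c1cc(-c2c(C(=O)NCC)noc2-c2cc(C(C)C)c(O)cc2O)on1`) has not yet been measured

All three compounds were or will be tested in a functional assay on HCT-116 cells (Homo sapiens) for inhibition; a lower number here means a stronger inhibitor, a higher number a weaker inhibitor. Compound 2 has no place on this scale, since its entry reads "not determined" (no result reported) and it offers no number to start from.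

One structural change leads onward (ethylamino in place of hydroxy on a carbonyl carbon). It puts ethylamino in place of hydroxy on a carbonyl carbon, so that the 3-carboxy-1,2-oxazol-5-yl group becomes a 3-(ethylcarbamoyl)-1,2-oxazol-5-yl group.

With no number for compound 2, the size of this step in this assay cannot be stated, and no direction can be expected with confidence. Within the data shown here, the only guide is compound 1 at 92 nM, so compound 3 is expected to fall in the same general range, and the range is kept wide. Compound 3 is estimated at 150 nM (expected range 40 nM to 600 nM).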

Compound 3, half-maximal inhibitory concentration: 14 nM
Beside the measured number, compound 3's estimate is 11-fold (1.03 log units) above it, outside the stated range (below it).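

In this assay this aromatic carbon now has its first step that can be read, and ethylcarbamoyl in place of (dimethylamino)methyl gives a 6.6-fold lower number from compound 1 to compound 3 (0.82 log units; beyond the scatter) with the rest of the molecule unchanged. A lower number means stronger inhibition, so activity at this place does not depend on the (dimethylamino)methyl group of compound 1, and among the groups with a number here ethylcarbamoyl gives the stronger inhibitor. Compound 2 has no number and its step to compound 3 cannot be read, so what ethylamino adds over hydroxy on the carbonyl carbon stays unknown, and nothing measured here gives a reason for the change.

The compounds shown leave open whether the gain belongs to the carbonyl-linked amide as a whole or to its ethyl chain, a question that a plain carbamoyl group, a methylcarbamoyl group or a longer chain such as propylcarbamoyl could help to settle. From the compounds shown here alone, it is also open how an ester such as ethoxycarbonyl or a simple amine such as aminomethyl would compare at this same place.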